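The source may report more compounds than this note shows. Statements on the series, on what has been measured and on what is new or still open speak of the compounds shown alone.

The measured compounds, each with its result in a functional assay on A549 cells (Homo sapiens) for antiproliferative activity, read by MTT assay, with a stated time of 72 h; on this read-out lower numbers stand for stronger inhibition and higher numbers for weaker inhibition:
Compound 1, `COc1cc(-n2cnc3ccc(-c4cccc(N)c4)cc32)cc(OC)c1OC`, gives 640 nM.
Compound 2, `COc1cc(-n2cnc3ccc(-c4ccc([N+](=O)[O-])cc4)cc32)cc(OC)c1OC`, gives 8940 nM.
Compound 3, `COc1cc(-n2cnc3ccc(-c4ccc(F)cc4)cc32)cc(OC)c1OC`, gives 6740 nM.

Compound 1 stands lowest of the three, and both of its neighbours lie well apart from it: the step of an 11-fold higher number from compound 1 to compound 3 (1.02 log units; beyond the scatter) and the step of a 14-fold higher number from compound 1 to compound 2 (1.15 log units; beyond the scatter) are each beyond the scatter, while compound 2 and compound 3 differ from each other by a 1.3-fold lower number from compound 2 to compound 3 (0.12 log units; within the scatter), which is within the scatter. Compound 4, `COc1cc(-n2cnc3ccc(-c4ccc(C)cc4)cc32)cc(OC)c1OC`, has not yet been measured. It differs from compound 1 as follows: 4-methylphenyl in place of 3-aminophenyl on an aromatic carbon. The two measured steps away from compound 1 bear directly on this change: each of them also swaps the 3-aminophenyl for another phenyl group with 0 hydrogen-bond donors, and each produced a large rise in the number. Whether methyl behaves more like fluoro or like nitro cannot be told from these data, but the two phenyl groups already tried gave numbers within the scatter of each other. A rise of similar size is therefore expected for compound 4, namely an 8.6-fold higher number from compound 1 to compound 4 (0.93 log units; beyond the scatter). The estimate for compound 4 in this assay is 5500 nM, with a range from 2000 nM to 15000 nM.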

Compound 4, half-maximal inhibitory concentration: 1940 nM
The estimate for compound 4 lay 2.8-fold (0.45 log units) above the measured number, and the stated range ends above it.
By their numbers in this assay, from the lowest: compound 1; then compound 4; then compounds 3 and 2 (each within the scatter of the next).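

In this assay, within the data shown here, the earlier compounds suggested that replacing the 3-aminophenyl with another phenyl group having no hydrogen-bond donor brings a large rise in the number, yet a 3.0-fold higher number from compound 1 to compound 4 (0.48 log units; beyond the scatter) is only a modest rise, even though compound 1 keeps the lowest number of the four. The group carried by the phenyl ring therefore matters even among groups with no hydrogen-bond donor: the nitro and fluoro compounds could not be told apart, but a 3.5-fold lower number from compound 3 to compound 4 (0.54 log units; beyond the scatter) and a 4.6-fold lower number from compound 2 to compound 4 (0.66 log units; beyond the scatter) set the methyl compound clearly apart from both. No measurement is available to explain why methyl gives a lower number than fluoro or nitro here.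

Compound 1 and compound 4 differ both in the group and in where it sits on the phenyl ring, so these compounds cannot show how much of the step comes from the amino group itself and how much from its place. A plain phenyl, or a phenyl carrying a hydroxyl, a methoxy or a longer chain such as ethyl, would show how far this trend extends beyond the groups seen so far.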